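This account rests on a few compounds, and the source may have more. Where it says the series, first, only, none or still open, it means among the compounds named here.

Two measured compounds share one core and are told apart by a single aryl group. In a functional assay on DU-145 cells (Homo sapiens) for antiproliferative activity, read by MTT assay, with a stated time of 24 h (a higher number here means a weaker inhibitor, a lower number a stronger inhibitor), compound 1 `COc1ccc(C(=O)/C=C/c2cc(-c3cc(OC)c(OC)c(OC)c3)n3nc(-c4ccccc4)cc3n2)cc1OC` gives 29900 nM and so stands at the top of the two numbers shown, though the gap to its only neighbour is within the scatter. In this assay compound 2 `COc1ccc(-c2cc(/C=C/C(=O)c3ccc(OC)c(OC)c3)nc3cc(-c4ccccc4)nn23)cc1` gives 16400 nM. The step of a 1.8-fold lower number from compound 1 to compound 2 (0.26 log units; within the scatter) concerns 4-methoxyphenyl in place of 3,4,5-trimethoxyphenyl on an aromatic carbon.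

Compound 3 `COc1cc(-c2cc(/C=C/C(=O)c3ccc(C)c(C)c3)nc3cc(-c4ccccc4)nn23)cc(OC)c1OC` has not yet been measured. It differs from compound 1 at the other end of the molecule, on the carbonyl carbon: 3,4-dimethylphenyl in place of 3,4-dimethoxyphenyl on a carbonyl carbon. No measured step touches that ring, so the one step shown does not bear on this change, and that step was itself within the scatter. With no guidance, no movement beyond the scatter is expected in this assay in either direction, which is what the expected step of a 1.0-fold higher number from compound 1 to compound 3 (0.00 log units; within the scatter) means. Compound 3 is therefore estimated at 30000 nM, with a likely range from 10000 nM to 90000 nM.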

Compound 3, half-maximal inhibitory concentration: 15400 nM
The estimate for compound 3 lay 1.9-fold (0.29 log units) above the measured number; low and high end bracket the measured number.
By their numbers in this assay, from the lowest: compounds 3, 2 and 1 (each within the scatter of the next).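

Going by these compounds alone, this is the first look at the far end of the molecule, the aryl group on the carbonyl carbon. In this assay, replacing 3,4-dimethoxyphenyl with 3,4-dimethylphenyl gives a 1.9-fold lower number from compound 1 to compound 3 (0.29 log units; within the scatter). The group that leaves carries 2 hydrogen-bond acceptors and the group that enters carries 0, yet the step stays within the scatter, so this swap at this position has no clear effect on the read-out. Nothing shown gives a measured reason for this result.

On these data alone, it remains open whether a carboxylic acid, an amine or a longer chain on this ring would shift the number beyond the scatter. As far as these compounds go, it is also open whether the same swap would read the same way on compound 2, which carries 4-methoxyphenyl at the other end.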